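Swapping the aryl group on a shared core

The source may hold more compounds than are shown below. What is called first, only, known or untested is meant among the compounds shown, and "the series" means these compounds.

Compound 1, `CN1CCN(CCCOc2cccc3nc(Nc4ccc(Cl)c(C(F)(F)F)c4)ccc23)CC1`: 1220 nM
Compound 2, `CC(C)c1ccc(Nc2ccc3c(OCCCN4CCN(C)CC4)cccc3n2)cc1`: 1940 nM
Compound 3, `CN1CCN(CCCOc2cccc3nc(Nc4ccc(F)c(F)c4)ccc23)CC1`: 960 nM

In a functional assay on HCT-15 cells (Homo sapiens) for inhibition, read by sulforhodamine B assay, with a stated time of 48 h (a higher number here means a weaker inhibitor of growth, a lower number a stronger inhibitor of growth), compound 3 sits at 960 nM. Its separation from compound 1 is small: a 1.3-fold lower number from compound 1 to compound 3 (0.10 log units; within the scatter). Only against compound 2 does it stand apart, since a 2.0-fold lower number from compound 2 to compound 3 (0.31 log units; beyond the scatter).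

Compound 4, `CN1CCN(CCCOc2cccc3nc(Nc4cc(Cl)cc(Cl)c4)ccc23)CC1`, changes the same aryl group: 3,5-dichlorophenyl in place of 3,4-difluorophenyl on a nitrogen on an aromatic ring. Three earlier swaps at this position bear on it, a 1.6-fold higher number from compound 1 to compound 2 (0.20 log units; within the scatter), a 1.3-fold lower number from compound 1 to compound 3 (0.10 log units; within the scatter) and a 2.0-fold lower number from compound 2 to compound 3 (0.31 log units; beyond the scatter), all small, and none exceeding a modest step. A change of similar size is therefore expected, with no clear direction, so that a 1.1-fold higher number from compound 3 to compound 4 (0.06 log units; within the scatter) is the expected step. Compound 4 is estimated at 1100 nM, expected to lie between 500 nM and 2500 nM.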

Compound 4, concentration for 50% growth inhibition: 1420 nM
Compound 4: the middle estimate sits 1.3-fold (0.11 log units) below what was measured, within the range that was stated.
By their numbers in this assay, from the lowest: compounds 3, 1, 4 and 2 (each within the scatter of the next, the first and the last beyond it).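

In this assay the change to 3,5-dichlorophenyl reads as a 1.5-fold higher number from compound 3 to compound 4 (0.17 log units; within the scatter) and the other two comparisons read as a 1.4-fold lower number from compound 2 to compound 4 (0.14 log units; within the scatter) and a 1.2-fold higher number from compound 1 to compound 4 (0.07 log units; within the scatter) so compound 4 cannot be told apart from any of the other three. It also bridges the one gap beyond the scatter, between compound 2 and compound 3, so these four aryl groups show no clear preference at this position. Nothing available gives a reason for these close values.

All four groups are substituted phenyl rings on the same nitrogen. Going by these compounds, whether an unsubstituted phenyl, a pyridine ring or a phenyl carrying a carboxylic acid would shift the number stays open.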